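The source may report more compounds than this note shows. Statements on the series, on what has been measured and on what is new or still open speak of the compounds shown alone.

In a functional assay on M21 cells (Homo sapiens) for antiproliferative activity, read by sulforhodamine B assay, with a stated time of 48 h (a lower number here means a stronger inhibitor, a higher number a weaker inhibitor), three compounds sharing one core differ only in a single group on an aromatic carbon. Compound 1 `O=C1NCCN1c1ccc(S(=O)(=O)Nc2ccc(F)cc2)cc1` gives 230 nM, and compound 2 `CCc1ccc(NS(=O)(=O)c2ccc(N3CCNC3=O)cc2)cc1` gives 480 nM. Compound 3 `CC(C)(C)c1ccc(NS(=O)(=O)c2ccc(N3CCNC3=O)cc2)cc1` gives > 1000 nM, which is a limit of the assay and not a number.

Compound 4 `CCCCCCOc1ccc(NS(=O)(=O)c2ccc(N3CCNC3=O)cc2)cc1` carries hexyloxy in place of tert-butyl on an aromatic carbon, para to a large group: hexyloxy in place of tert-butyl on an aromatic carbon. Three measured steps at this same place bear on the change. They show a 2.1-fold higher number from compound 1 to compound 2 (0.32 log units; beyond the scatter), an at least 4.3-fold higher number from compound 1 to compound 3 (0.63 log units; beyond the scatter) and an at least 2.0-fold higher number from compound 2 to compound 3 (0.31 log units; beyond the scatter), each of modest size or more and all in the weaker direction. Among these three compounds, the number climbs from fluoro through ethyl to tert-butyl, and none goes against that order. None of them carries hexyloxy, so this is a cautious extension, and a weak result is expected rather than a recovery. The estimated step is a step that the limit leaves unreadable from compound 3 to compound 4. For compound 4 the estimated value is 1500 nM, with an expected range from 500 nM to 5000 nM.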

Compound 4, half-maximal inhibitory concentration: > 1000 nM
Compound 4: a limit, no number (the forecaster's own chance of this, stated with the estimate: 60%); the middle value lies beyond the limit too.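

In this assay, hexyloxy joins the weaker end of this position, with an at least 4.3-fold higher number from compound 1 to compound 4 (0.63 log units; beyond the scatter) and an at least 2.0-fold higher number from compound 2 to compound 4 (0.31 log units; beyond the scatter). The weakening seen with ethyl and tert-butyl therefore extends to a group of a different kind, a chain joined to the ring through oxygen, and no compound shown goes against this order. The step from compound 3 to compound 4 cannot be read, so tert-butyl and hexyloxy cannot be ranked against each other: the limit of > 1000 nM in this assay, at which 2 of the 4 values shown sit.

A shorter chain on the same oxygen, such as methoxy, could show whether the oxygen or the length of the chain matters more here. On these data alone, it also remains open whether an amine or a carboxylic acid at this place would improve on compound 1, at 230 nM.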